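The compounds below may be only part of what the source reports. "The series", "measured", "known", "first", "only" and "open" are said of these compounds alone.

Compound 2 `CN(C)S(=O)(=O)NC[C@@H]1CCCc2cc(S(=O)(=O)c3cccc(F)c3)ccc21` is one of two compounds examined in an assay on isolated protein for displacement of a labelled ligand from 5-hydroxytryptamine receptor 6 (Homo sapiens) (on this read-out higher numbers stand for weaker inhibition and lower numbers for stronger inhibition), where compound 2 gives 2 nM. Compound 1 `CNC[C@@H]1CCCc2cc(S(=O)(=O)c3cc[nH]c3)ccc21` gives 0.159 nM in this assay, so compound 2 stands at the higher of the two numbers, with a gap to compound 1 that lies beyond the usual scatter. Compound 3 `NCC(=O)NC[C@@H]1CCCc2cc(S(=O)(=O)c3cccc(F)c3)ccc21` is not yet measured. It differs from compound 2 by a single change ((aminomethyl)carbonyl in place of dimethylsulfamoyl on an amine nitrogen). For the measured compounds named here, no measured pair shows this change, so its effect is unknown. The step from compound 2 to compound 3 in this assay is expected to be small and to fall within the scatter, a 1.1-fold lower number from compound 2 to compound 3 (0.05 log units; within the scatter). Compound 3 is therefore estimated at 1.8 nM, with a range from 0.5 nM to 7 nM.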

Compound 3, inhibition constant: 0.316 nM
The estimate for compound 3 lay 5.7-fold (0.76 log units) above the measured number, outside the stated range (below it).
By their numbers in this assay, from the lowest: compounds 1 and 3 (each within the scatter of the next); then compound 2.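

On an amine nitrogen whose other neighbour is a saturated chain carbon, (aminomethyl)carbonyl in place of dimethylsulfamoyl gives a 6.3-fold lower number from compound 2 to compound 3 (0.80 log units; beyond the scatter) in this assay. For the compounds shown here, this shows that the number in this assay responds to the group on this nitrogen, which the earlier compounds could not show, though the finding rests on this single pair. Whether the step depends on the amine of (aminomethyl)carbonyl stays open, as the compounds shown include no acetyl group or longer aminoalkyl chain on this nitrogen. No available evidence bears on the reason for the step.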